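Swapping one phenyl group for another on a sulfonamide

The source may report more compounds than this note shows. Statements on the series, on what has been measured and on what is new or still open speak of the compounds shown alone.

Of the compounds shown here, three built on a shared core have been measured in a physicochemical assay for lipophilicity, at pH 7.4; on this read-out lower numbers stand for lower lipophilicity and higher numbers for higher lipophilicity. Among them, compound 3 `O=S(=O)(Nc1ccccc1C(F)(F)F)c1ccc2c(c1)C(O)CC(C1CCOCC1)O2` gives 2.41. Its neighbour compound 1 `CCc1ccc(N(C2COC2)S(=O)(=O)c2ccc3c(c2)C(O)CC(C2CCOCC2)O3)cc1` gives 2.63, which lies within the usual scatter of compound 3. By contrast, compound 2 `CCc1ccc(N(CC(C)C)S(=O)(=O)c2ccc3c(c2)C(O)CC(C2CCOCC2)O3)cc1` stands clearly higher, at 4.12.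

The unmeasured compound 4 `CCc1ccc(NS(=O)(=O)c2ccc3c(c2)C(O)CC(C2CCOCC2)O3)cc1` differs from compound 3 in one place, on a sulfonamide nitrogen whose other neighbour is the sulfonyl sulfur. There, 4-ethylphenyl stands in place of 2-(trifluoromethyl)phenyl (4-ethylphenyl in place of 2-(trifluoromethyl)phenyl on a sulfonamide nitrogen).

Within the data shown here, no measured pair makes this exact exchange. The closest evidence is a different exchange on a sulfonamide nitrogen, a number 1.49 log units higher from compound 1 to compound 2 (beyond the scatter). That large step shows that, in this pair, one group at such a nitrogen can move this assay a long way.

Compound 4 shares its 4-ethylphenyl group with compound 1, which gives 2.63, and with compound 2, which gives 4.12. Its number is therefore expected to fall between those two. The expected change is a number 0.69 log units higher from compound 3 to compound 4 (beyond the scatter), upward and smaller than the large step above. For compound 4 the estimate is 3.1, with an expected range from 2.6 to 3.7.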

Compound 4, distribution coefficient: 2.59
Estimate against measurement, compound 4: 0.51 log units above; measured number below the stated range.
By their numbers in this assay, from the lowest: compounds 3, 4 and 1 (each within the scatter of the next); then compound 2.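

In this assay, 4-ethylphenyl in place of 2-(trifluoromethyl)phenyl on a sulfonamide nitrogen is a small exchange (a number 0.18 log units higher from compound 3 to compound 4 (within the scatter)), so this pair cannot be told apart on this read-out. Compound 4 also gives the nitrogen a reference with only hydrogen on it and 4-ethylphenyl held fixed: hydrogen in place of isobutyl is a large change (a number 1.53 log units lower from compound 2 to compound 4 (beyond the scatter)), whereas hydrogen in place of oxetan-3-yl is not (a number 0.04 log units lower from compound 1 to compound 4 (within the scatter)), so among these three compounds the big movement appears only with isobutyl present. Nothing available here accounts for these numbers, and the data show only the size of each change, not what lies behind it.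

The compounds shown leave open whether isobutyl would give a similarly large step with 2-(trifluoromethyl)phenyl on the same nitrogen, since every isobutyl comparison here has 4-ethylphenyl. They also leave open how a longer chain on that nitrogen, or an amine or a carboxylic acid on its phenyl group, would move the number in this assay.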